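Trimming two methyl groups from a thiophene-bearing guanylhydrazone

The source may hold more compounds than are shown below. What is called first, only, known or untested is meant among the compounds shown, and "the series" means these compounds.

Measured compounds:
- compound 1, `Cc1cc(-c2nc3sc(C)cn3c2/C=N/NC(=N)N)c(C)s1`, 25100 nM
- compound 2, `Cc1cn2c(/C=N/Nc3ccccn3)c(-c3ccc(Cl)c([N+](=O)[O-])c3)nc2s1`, 30900 nM

Both compounds were tested in a functional assay on cells (Cancer cell lines, Homo sapiens) for inhibition; a higher number here means a weaker inhibitor of growth, a lower number a stronger inhibitor of growth. Compound 1 gives 25100 nM, and compound 2 gives 30900 nM. Compound 1 has the lower of the two numbers, but the gap to compound 2 lies within the scatter, so the two cannot be told apart on these data.

Compound 3, `Cc1cn2c(/C=N/NC(=N)N)c(-c3ccsc3)nc2s1`, has not yet been measured. Compared with compound 1 the change is thiophen-3-yl in place of 2,5-dimethylthiophen-3-yl on an aromatic carbon. Both compounds share the same core and the same guanylhydrazone arm; only the two methyl groups on the thiophene are gone.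

Among the measured compounds shown here, no pair of measured compounds differing in one place exists here, so no direct step can be read off. For the measured compounds named here, with only two methyl groups removed, the expected step from compound 1 to compound 3 in this assay is small, a 1.2-fold higher number from compound 1 to compound 3 (0.08 log units; within the scatter), and may not exceed the scatter in either direction. Compound 3 is therefore estimated at 30000 nM, with a range from 10000 nM to 100000 nM.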

Compound 3, concentration for total growth inhibition: 41700 nM
Estimate against measurement, compound 3: 1.4-fold (0.14 log units) below; low and high end bracket the measured number.
By their numbers in this assay, from the lowest: compounds 1, 2 and 3 (each within the scatter of the next).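

In this assay, among the compounds shown here, the exchange of 2,5-dimethylthiophen-3-yl for thiophen-3-yl gives a 1.7-fold higher number from compound 1 to compound 3 (0.22 log units; within the scatter) and is the first direct comparison at this position, which the two earlier compounds could not offer because they differ in more than one place. Taking both methyl groups off the thiophene therefore produces no difference that can be separated from the ordinary spread of repeat measurements, so at this aromatic carbon the bare ring and the dimethylated ring cannot be told apart in this test of growth inhibition. Nothing measured here speaks to the reason for the size of this step.

Each methyl group has been tested only together with the other, so a thiophene carrying a single methyl group could show whether either one matters alone. From the compounds shown here alone, it also remains open whether something quite different on this carbon, such as a plain phenyl ring, an amine, a carboxylic acid or a longer alkyl chain, would shift the number beyond the scatter.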